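The source may report more compounds than this note shows. Statements on the series, on what has been measured and on what is new or still open speak of the compounds shown alone.

Of the compounds shown here, three have so far been measured in an assay for binding affinity to 17-beta-hydroxysteroid dehydrogenase 14 (Homo sapiens), read by fluorescence, with a stated time of 15 min, in the presence of a further agent that is not named here; on this read-out higher numbers stand for weaker inhibition and lower numbers for stronger inhibition. Compound 1 `N#Cc1ccc2ccc(C(=O)c3ccc(F)c(O)c3)nc2c1` gives 9 nM. Compound 2 `Nc1ccc2ccc(C(=O)c3ccc(F)c(O)c3)nc2c1` gives 34 nM, and compound 3 `CN(C(=O)c1ccc(F)c(O)c1)c1cccc(-c2cccc(O)c2F)n1` gives 2030 nM. Compound 2 therefore stands second highest of the three numbers: compound 1 is its nearest neighbour and compound 3 its furthest. Among the measured compounds shown here, the only step between two compounds that differ in a single place is a 3.8-fold higher number from compound 1 to compound 2 (0.58 log units; beyond the scatter), a modest rise in the number when amino replaced cyano on an aromatic carbon.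

Compound 4 `O=C(O)CNc1ccc2ccc(C(=O)c3ccc(F)c(O)c3)nc2c1` has not yet been measured. It differs from compound 2 in one place: carboxymethyl in place of hydrogen on a nitrogen on an aromatic ring. For the measured compounds named here, no measured step alters what sits on this nitrogen. Going by the values given here, the single step available, which exchanged the whole group on the aromatic carbon, moved the number by a modest amount, so it suggests that changes in this part of the molecule are tolerated but not without cost. A step of similar modest size is therefore expected, most likely towards a higher number, though a value within the scatter of compound 2 would not be surprising. The expected step is a 1.8-fold higher number from compound 2 to compound 4 (0.25 log units; within the scatter). In this assay compound 4 is estimated at 60 nM, with a range from 15 nM to 250 nM.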

Compound 4, inhibition constant: 23 nM
For compound 4 the middle estimate is 2.6-fold (0.42 log units) above the measured one, and the stated range covers the measured number.
By their numbers in this assay, from the lowest: compound 1; then compounds 4 and 2 (each within the scatter of the next); then compound 3.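

In this assay, among the compounds shown here, putting carboxymethyl in place of hydrogen on the nitrogen on the aromatic ring gives a 1.5-fold lower number from compound 2 to compound 4 (0.17 log units; within the scatter), so the first change at this nitrogen leaves the number within the scatter, even though the entering group brings 4 heavy atoms and the earlier compounds left this nitrogen untouched. The wider exchange on the aromatic carbon, (carboxymethyl)amino in place of cyano, gives a 2.6-fold higher number from compound 1 to compound 4 (0.41 log units; beyond the scatter), a modest difference beyond the scatter, so the nitrile-bearing compound 1 keeps the lowest number of this closely related set. Nothing here explains why the number holds when this group is added.

Compound 4 cannot show whether the carboxylic acid matters or whether the nitrogen would accept almost any group, and a simple methyl, a methyl ester or a hydroxyethyl chain on the same nitrogen would help to separate those two readings. On these data alone, how far the chain can grow also stays open, since a longer chain such as a carboxypropyl group or one ending in an amine could behave quite differently from carboxymethyl.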